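Swapping the phenyl for dichlorophenyl on the ring amine

The source may report more compounds than this note shows. Statements on the series, on what has been measured and on what is new or still open speak of the compounds shown alone.

Compound 1 `CC1(c2ccccc2)CC(=O)N(CC(=O)N2CCN(c3ccccc3)CC2)C1=O` carries a plain phenyl on the ring nitrogen of its piperazine-like unit. In a functional assay on the whole organism (strain CD-1) with Mus musculus as the target, in the maximal electroshock model, with a stated time of 2 h (on this read-out lower numbers stand for an effect already at smaller amounts and higher numbers for an effect only at larger amounts of compound), compound 1 is reported as "not active" (no number reported), so no dose number stands for it. Two close relatives were also tested: compound 2 `CC1(c2ccccc2)CC(=O)N(CC(=O)N2CCN(c3ccc(F)cc3)CC2)C1=O` gives 100 mg/kg in this assay, while compound 3 `CC1(c2ccccc2)CC(=O)N(CC(=O)N2CCN(c3ccc(Cl)cc3)CC2)C1=O` is reported as "not active" (no number reported) there. Compound 4 `CC1(c2ccccc2)CC(=O)N(CC(=O)N2CCN(c3ccc(Cl)c(Cl)c3)CC2)C1=O` is not yet measured; it differs from compound 1 by 3,4-dichlorophenyl in place of phenyl on an amine nitrogen in a ring. Going by the values given here, no step between measured compounds can be computed, and since compound 1 has no number, no direction in this assay can be stated beyond the scatter. Compound 4 is expected to reach about 200 mg/kg, within 60 mg/kg to 600 mg/kg.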

Compound 4, minimum effective dose: 300 mg/kg
The estimate for compound 4 lay 1.5-fold (0.18 log units) below the measured number; low and high end bracket the measured number.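

In this assay compound 4 gives 300 mg/kg with its 3,4-dichlorophenyl on the amine nitrogen, whereas compound 1 and compound 3 have no number, so steps involving them cannot be read. Replacing 4-fluorophenyl with 3,4-dichlorophenyl gives a 3.0-fold higher number from compound 2 to compound 4 (0.48 log units; beyond the scatter) and so shows that the choice of aryl group at this position can shift the dose needed. Nothing available explains this shift. Still open, going by these compounds, is how a methoxy group or an amine on this phenyl ring would behave. On these data alone, a pyridine in place of the phenyl ring is equally open.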